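The compounds below may be only part of what the source reports. "The series", "measured", "known", "first", "only" and "open" are said of these compounds alone.

Measured in a functional assay on K562 cells (Homo sapiens), read by MTT assay, with a stated time of 72 h; a higher number here means a weaker inhibitor, a lower number a stronger inhibitor:
- compound 1 `CSc1ncnc2c1c(-c1ccsc1)cn2[C@@H]1O[C@H](CO)[C@@H](O)[C@H]1O`: > 20000 nM
- compound 2 `CN(C)c1ncnc2c1c(-c1ccsc1)cn2[C@@H]1O[C@H](CO)[C@@H](O)[C@H]1O`: > 20000 nM
- compound 3 `CN(C)c1ncnc2c1c(-c1cc3ccccc3o1)cn2[C@@H]1O[C@H](CO)[C@@H](O)[C@H]1O`: > 20000 nM

Each entry is a limit of the assay, not a number. Compound 2 therefore has no exact place, and the whole set shows (the limit of > 20000 nM in this assay, at which 3 of the 3 values shown sit).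

Compound 4 `Cc1ncnc2c1c(-c1ccsc1)cn2[C@@H]1O[C@H](CO)[C@@H](O)[C@H]1O` carries methyl in place of dimethylamino on an aromatic carbon.

The closest measured change is a step that the two limits leave unreadable from compound 1 to compound 2, which also concerns dimethylamino. The other is a step that the two limits leave unreadable from compound 2 to compound 3, which concerns a different group. Because of the limit of > 20000 nM in this assay, at which 3 of the 3 values shown sit, neither gives a size to build on. Only a cautious shift toward stronger inhibition in this assay is expected, and another limit remains quite possible.

The expected change is an at least 4.0-fold lower number from compound 2 to compound 4 (0.60 log units; beyond the scatter).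

Compound 4 is estimated at 5000 nM, with an expected range of 300 nM to 30000 nM.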

Compound 4, half-maximal inhibitory concentration: 5550 nM
Compound 4: middle estimate off by 1.1-fold (0.05 log units), on the low side, and the stated range covers the measured number.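

In this assay compound 4 is the only one of the four with an exact number, which shows that changing the group at this position on the shared core can move the read-out. Methyl in place of dimethylamino gives an at least 3.6-fold lower number from compound 2 to compound 4 (0.55 log units; beyond the scatter), and methyl in place of methylsulfanyl gives an at least 3.6-fold lower number from compound 1 to compound 4 (0.55 log units; beyond the scatter); each starting compound sits at a limit of the assay, so the true sizes stay open. The steps among the earlier compounds cannot be read: the limit of > 20000 nM in this assay, at which 3 of the 4 values shown sit.

From the compounds shown here alone, whether an ethyl group, a longer chain or a primary amine at this position would give a lower number remains open. So does whether methyl has the same effect with 1-benzofuran-2-yl in place of thiophen-3-yl.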